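Seven-membered diamine series: cyclopentyl replacing neopentyl

The source may hold more compounds than are shown below. What is called first, only, known or untested is meant among the compounds shown, and "the series" means these compounds.

Compound 3 `CC(C)(C)CN1CCCN(CCn2ccc3ccc(Br)cc32)CC1` stands at the top of the numbers measured in an assay on HEK293 cells for binding affinity to 5-hydroxytryptamine receptor 7 (Homo sapiens), read by radioligand binding (on this read-out higher numbers stand for weaker inhibition and lower numbers for stronger inhibition), where compound 3 gives 163 nM. Compound 1 `CN1CCCN(CCn2ccc3ccc(Br)cc32)CC1` gives 31 nM and compound 2 `CC(C)N1CCCN(CCn2ccc3ccc(Br)cc32)CC1` gives 14 nM. The step from the methyl compound to the neopentyl compound was a 5.3-fold higher number from compound 1 to compound 3 (0.72 log units; beyond the scatter), and that from the isopropyl compound to the neopentyl compound was a 12-fold higher number from compound 2 to compound 3 (1.07 log units; beyond the scatter); the step of a 2.2-fold lower number from compound 1 to compound 2 (0.35 log units; beyond the scatter) shows the isopropyl compound as the lower of the two.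

Compound 4 `Brc1ccc2ccn(CCN3CCCN(C4CCCC4)CC3)c2c1` differs from compound 3 by cyclopentyl in place of neopentyl on an amine nitrogen in a ring. Cyclopentyl, like isopropyl, sits directly on the ring nitrogen, whereas neopentyl reaches it through a chain carbon. The step from compound 2 to compound 3 is the most relevant comparison, and a return toward the region of compound 2 and compound 1 is expected, though not necessarily all of the way. Compound 4 is therefore expected to give about 25 nM in this assay, within 8 nM to 80 nM, an expected step of a 6.5-fold lower number from compound 3 to compound 4 (0.81 log units; beyond the scatter).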

Compound 4, inhibition constant: 10 nM
For compound 4 the middle estimate is 2.5-fold (0.40 log units) above the measured one, and the stated range covers the measured number.
By their numbers in this assay, from the lowest: compounds 4 and 2 (each within the scatter of the next); then compound 1; then compound 3.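

In this assay, the amine nitrogen in the ring accepts a cyclopentyl group: a 16-fold lower number from compound 3 to compound 4 (1.21 log units; beyond the scatter), although neopentyl and cyclopentyl both have 5 heavy atoms, so heavy-atom count alone does not set the number at this position. With a 1.4-fold lower number from compound 2 to compound 4 (0.15 log units; within the scatter), compound 2 and compound 4 cannot be ordered, whereas a 3.1-fold lower number from compound 1 to compound 4 (0.49 log units; beyond the scatter) places the cyclopentyl compound on the stronger side of the methyl compound. No measurement shown here accounts for the gap between the neopentyl and cyclopentyl compounds.

As far as these compounds go, whether cyclopropyl or cyclohexyl on the same nitrogen stays at the level of compound 2 and compound 4 remains open. Also open, from the compounds shown here alone, is how a ring containing oxygen, such as tetrahydropyranyl, behaves there.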